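Chloro on the Ring Next to the Core of Compound 3

This account rests on a few compounds, and the source may have more. Where it says the series, first, only, none or still open, it means among the compounds named here.

Compound 1, `CN(Cc1ccc2nccn2c1)c1nnc(-c2ccc(C3CC3)cc2)o1`, gives 20000 nM in an assay on isolated protein for inhibition of tyrosine-protein kinase receptor UFO (Homo sapiens), read by LC-MS; on this read-out lower numbers stand for stronger inhibition and higher numbers for weaker inhibition.
Compound 2, `CN(Cc1ccc2nccn2c1)c1nnc(-c2ccc(-c3ccccc3)cc2)o1`, gives 3160 nM in this assay.
Compound 3, `Cc1nn(C)c(C)c1-c1ccc(-c2nnc(N(C)Cc3ccc4nccn4c3)o2)cc1`, gives 1260 nM in this assay.

Compound 3 stands lowest of the three: a 16-fold lower number from compound 1 to compound 3 (1.20 log units; beyond the scatter) and a 2.5-fold lower number from compound 2 to compound 3 (0.40 log units; beyond the scatter), both beyond the scatter. Compound 4, `Cc1nn(C)c(C)c1-c1ccc(-c2nnc(N(C)Cc3ccc4nccn4c3)o2)c(Cl)c1`, differs from compound 3 by chloro in place of hydrogen on an aromatic carbon. Going by the values given here, no measured step concerns a chloro; the three steps measured, among them a 6.3-fold lower number from compound 1 to compound 2 (0.80 log units; beyond the scatter), all exchange the whole group on that aromatic carbon, so they do not bear on this change. Compound 4 is therefore expected to show no step beyond the scatter, a 1.3-fold lower number from compound 3 to compound 4 (0.10 log units; within the scatter). Compound 4 is estimated at 1000 nM in this assay, within a range from 350 nM to 3000 nM.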

Compound 4, half-maximal inhibitory concentration: 79.4 nM
Compound 4: the middle estimate sits 13-fold (1.10 log units) above what was measured, outside the stated range (below it).
By their numbers in this assay, from the lowest: compound 4; then compound 3; then compound 2; then compound 1.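

In this assay chloro in place of hydrogen gives a 16-fold lower number from compound 3 to compound 4 (1.20 log units; beyond the scatter) and so matches in size the exchange of a whole group seen in a 16-fold lower number from compound 1 to compound 3 (1.20 log units; beyond the scatter) on the far smaller change of one heavy atom. Compounds 1, 2 and 3 all carry hydrogen on this aromatic carbon, ortho to a large group and meta to the 1,3,5-trimethyl-1H-pyrazol-4-yl group, so only compound 4 shows that this position answers so strongly to a substituent.

From the compounds shown here alone, whether fluoro, bromo, methyl or methoxy on the same carbon would give a step of like size remains open. The compounds shown offer no measurement that accounts for the step.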